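A few compounds are considered here, and "the series" means these few. Any claim that something is new, unique, unknown or untested is made for them only; others in the source may bear on it.

Measured in a functional assay on PC-3 cells (Homo sapiens) for antiproliferative activity, with a stated time of 48 h; a lower number here means a stronger inhibitor, a higher number a weaker inhibitor:
- Compound 1 `CCOC(=O)c1ccc(-c2ccc(N(CC)CC)nn2)cc1`: 1000 nM
- Compound 2 `CCOC(=O)c1ccc(-c2ccc(N(C)C)nn2)cc1`: > 25000 nM (a limit, not a number)
- Compound 3 `COC(=O)c1ccc(-c2ccc(N(C)C)nn2)cc1`: > 25000 nM (a limit, not a number)

Compound 2 has no exact value, only the limit > 25000 nM. It therefore stands among the compounds at the limit of > 25000 nM in this assay, at which 2 of the 3 values shown sit, and any change from it can be read only if the new compound gives a real number.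

Compound 4 `CCOC(=O)c1ccc(-c2ccc(OCC)nn2)cc1` is unmeasured. It keeps the rest of compound 2 but carries ethoxy in place of dimethylamino on an aromatic carbon.

The most relevant evidence comes from the same carbon, where dimethylamino in place of diethylamino gives an at least 25-fold higher number from compound 1 to compound 2 (1.39 log units; beyond the scatter). Among the compounds with values here, that large step shows that a change on this carbon can move the number a long way, but it involves no ethoxy compound. The other measured change gives a step that the two limits leave unreadable from compound 2 to compound 3, so it offers no guide to size or direction.

A moderate move to a lower number is therefore expected, though with low confidence, and a result that stays at the limit would be no surprise. The estimate means an expected at least 2.0-fold lower number from compound 2 to compound 4 (0.31 log units; beyond the scatter). For compound 4 the estimated value is 12000 nM, with an expected range of 2500 nM to 25000 nM.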

Compound 4, half-maximal inhibitory concentration: > 25000 nM
Compound 4: no number, only a limit; the forecaster's own chance of this, stated with the estimate: 55%; middle value at least 2.0-fold (0.31 log units) from the limit.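

In this assay compound 4 gives > 25000 nM, which is a limit and not a number. Diethylamino is exchanged here for a group that puts an oxygen on the aromatic carbon instead of a nitrogen, and this gives an at least 25-fold higher number from compound 1 to compound 4 (1.39 log units; beyond the scatter), so a second, different replacement of diethylamino at this position also loses the exact value seen for compound 1. Compound 4 now sits with compound 2 and compound 3, and the steps between these limits cannot be read: the limit of > 25000 nM in this assay, at which 3 of the 4 values shown sit.

Among the compounds shown, diethylamino is the only group at this position that gives an exact value, but how far compound 2 and compound 4 lie from each other remains unknown, so neither dimethylamino nor ethoxy can be ranked against the other. On these data alone, it also remains open whether a longer chain on the nitrogen, such as dipropylamino, or a longer chain on the oxygen, such as butoxy, would bring the result back to a measurable number.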